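This account rests on a few compounds, and the source may have more. Where it says the series, first, only, none or still open, it means among the compounds named here.

Working notes on the series.

Of the compounds shown here, two of the shared core have been measured in an assay on CCRF-CEM cells for antagonist activity at C-C chemokine receptor type 4 (Homo sapiens), read by CellTiter-Glo, with stated times of 30 min and 60 min, in the presence of a further agent that is not named here; on this read-out lower numbers stand for stronger inhibition and higher numbers for weaker inhibition. Compound 1 `Cc1nn([C@H](C)c2ccc(Cl)cc2Cl)c2nc(N3CC[C@H](N4CCC[C@H]4CCC#N)[C@H](C)C3)cnc12` gives 865 nM. Compound 2 `Cc1nn([C@H](C)c2ccc(Cl)cc2Cl)c2nc(N3CC[C@H](N4CCC[C@H]4CO)[C@H](C)C3)cnc12` gives 151 nM. For the measured compounds named here, the one measured step is a 5.7-fold lower number from compound 1 to compound 2 (0.76 log units; beyond the scatter), which puts compound 2 at the lowest of the two numbers, with compound 1 the only neighbour.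

Compound 3 `Cc1nn([C@H](C)c2ccc(Cl)cc2Cl)c2nc(N3CC[C@H](N4CCCCCC4)[C@H](C)C3)cnc12` differs from compound 2 by azepan-1-yl in place of 2-(hydroxymethyl)pyrrolidin-1-yl on a saturated ring carbon. Going by the values given here, the only measured step that touches this part of the structure is a 5.7-fold lower number from compound 1 to compound 2 (0.76 log units; beyond the scatter); it was a modest step, and it shows that the group carried on the five-membered ring can move the number beyond the scatter. For compound 3 the whole five-membered ring and its hydroxymethyl are gone and a seven-membered ring without a donor takes their place, so a step back toward the number of compound 1 is the likely outcome, of modest size.

Compound 3 is therefore expected to give about 500 nM in this assay, within 150 nM to 1700 nM. That estimate means a 3.3-fold higher number from compound 2 to compound 3 (0.52 log units; beyond the scatter), an expected rise in the number.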

Compound 3, half-maximal inhibitory concentration: 195 nM
Estimate against measurement, compound 3: 2.6-fold (0.41 log units) above; the range from low to high includes it.
By their numbers in this assay, from the lowest: compounds 2 and 3 (each within the scatter of the next); then compound 1.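

Azepan-1-yl in place of 2-(hydroxymethyl)pyrrolidin-1-yl on the saturated ring carbon gives a 1.3-fold higher number from compound 2 to compound 3 (0.11 log units; within the scatter) in this assay, so within this pair neither the hydroxymethyl group, with its 1 hydrogen-bond donor, nor the defined stereocentre of the leaving group is needed to hold the number at this level. The same azepan-1-yl against the 2-(2-cyanoethyl)pyrrolidin-1-yl of compound 1 gives a 4.4-fold lower number from compound 1 to compound 3 (0.65 log units; beyond the scatter) and so shows this position tolerating a seven-membered ring with 0 hydrogen-bond donors, which makes compound 1 the one that stands apart among the three rather than compound 2. Nothing available here explains why the numbers fall this way.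

The compounds shown leave open whether plain pyrrolidin-1-yl or piperidin-1-yl at this position would sit with compound 2 and compound 3, which would separate the effect of ring size from that of the substituent on the ring. They also leave open how a primary amine, a carboxylic acid or a longer hydroxyalkyl chain on the five-membered ring would read in this assay.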